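Formyl in Place of Difluoromethyl: What the Numbers Suggest

The source may hold more compounds than are shown below. What is called first, only, known or untested is meant among the compounds shown, and "the series" means these compounds.

Three compounds have so far been measured in a functional assay on HEK293 cells for antagonist activity at transient receptor potential cation channel subfamily V member 1 (Rattus norvegicus); a lower number here means a stronger inhibitor, a higher number a weaker inhibitor:
Compound 1, `Cc1cccnc1N1CCN(C(=O)Nc2ccc(C(C)C)cc2)CC1`, gives 173 nM.
Compound 2, `CCc1cccnc1N1CCN(C(=O)Nc2ccc(C(C)C)cc2)CC1`, gives 828 nM.
Compound 3, `CC(C)c1ccc(NC(=O)N2CCN(c3ncccc3C(F)F)CC2)cc1`, gives 61.5 nM.

Compound 3 has the lowest number of the three. Its nearest neighbour is compound 1, and the step of a 2.8-fold lower number from compound 1 to compound 3 (0.45 log units; beyond the scatter) is modest; the step of a 13-fold lower number from compound 2 to compound 3 (1.13 log units; beyond the scatter) is large. Between the two weaker compounds the step of a 4.8-fold higher number from compound 1 to compound 2 (0.68 log units; beyond the scatter) runs the other way. Compound 4, `CC(C)c1ccc(NC(=O)N2CCN(c3ncccc3C=O)CC2)cc1`, has not yet been measured. It differs from compound 3 in one place: formyl in place of difluoromethyl on an aromatic carbon.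

Among the compounds with values here, no measured step exchanges a difluoromethyl for a formyl, so the expectation rests on indirect evidence. The two measured steps that end at compound 3, a 2.8-fold lower number from compound 1 to compound 3 (0.45 log units; beyond the scatter) and a 13-fold lower number from compound 2 to compound 3 (1.13 log units; beyond the scatter), show that the difluoromethyl gives the lowest number among the three groups tried at this carbon, and that each of the other two groups tried there gave a higher number. Compound 4 carries yet another group there, and a modest rise in this assay is therefore expected, with the step of a 2.4-fold higher number from compound 3 to compound 4 (0.39 log units; beyond the scatter). Compound 4 is estimated at 150 nM, with a range from 50 nM to 500 nM.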

Compound 4, half-maximal inhibitory concentration: 1400 nM
Compound 4: middle estimate off by 9.3-fold (0.97 log units), on the low side; the whole stated range lies below it.
By their numbers in this assay, from the lowest: compound 3; then compound 1; then compounds 2 and 4 (each within the scatter of the next).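

In this assay, the step of a 23-fold higher number from compound 3 to compound 4 (1.36 log units; beyond the scatter) shows that this carbon of the 3-(difluoromethyl)pyridin-2-yl group does not accept just any small replacement: exchanging difluoromethyl for formyl, which swaps the fluorines for a single oxygen and brings in one hydrogen-bond acceptor, gives up all of the advantage compound 3 held. The step of a 1.7-fold higher number from compound 2 to compound 4 (0.23 log units; within the scatter) lies within the scatter, so formyl and ethyl cannot be told apart here, although the two groups differ in kind. The step of an 8.1-fold higher number from compound 1 to compound 4 (0.91 log units; beyond the scatter) then shows that formyl also falls short of methyl, so among the groups tried only methyl and difluoromethyl keep the number low, and compound 4 shows that a single carbon bound to the ring is not enough on its own to do so.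

Nothing available accounts for the rise seen with the formyl group. Still open, from the compounds shown here alone, is whether a trifluoromethyl, a nitrile or a hydroxymethyl at this carbon would group with difluoromethyl and methyl or with formyl and ethyl, and whether the same exchange would cost as much on a different core.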